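The compounds below may be only part of what the source reports. "The series", "measured", "known", "first", "only" and "open" are said of these compounds alone.

Two measured compounds frame this step. Compound 1 `O=C(Nc1cccc(-n2cc(-c3ccncc3)c(-c3ccc(Cl)c(O)c3)n2)c1)Nc1cccc(C(F)(F)F)c1` is the weaker of the pair: in a functional assay on MDA-MB-435 cells (Homo sapiens) for inhibition, read by sulforhodamine B assay, with a stated time of 48 h (on this read-out higher numbers stand for weaker inhibition of growth and lower numbers for stronger inhibition of growth), compound 1 gives 12600 nM. Compound 2 `COc1cc(-c2nn(-c3cccc(NC(=O)Nc4cc(C(F)(F)F)cc(C(F)(F)F)c4)c3)cc2-c2ccncc2)ccc1Cl` carries the lowest of the two numbers; in this assay compound 2 gives 1990 nM, and its nearest neighbour, compound 1, stands clearly higher, a gap beyond the usual scatter. For the measured compounds named here, compound 1 and compound 2 differ in more than one place, so no single step between measured compounds is available, and their two values are all that can be read.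

Compound 3 `O=C(Nc1cccc(-n2cc(-c3ccncc3)c(-c3ccc(Cl)c(O)c3)n2)c1)Nc1cc(C(F)(F)F)cc(C(F)(F)F)c1` is drawn from compound 2 by one change: hydrogen in place of methyl on an oxygen on an aromatic ring. The same shift, cut one bond further out, reads methoxy to hydroxy, that is 4-chloro-3-methoxyphenyl to 4-chloro-3-hydroxyphenyl. Nothing in the measured pair isolates this change, so the direction rests on judgement alone. The step from compound 2 to compound 3 is expected to be small, a 1.5-fold higher number from compound 2 to compound 3 (0.18 log units; within the scatter), likely within or just beyond the scatter. Compound 3 is therefore estimated in this assay at 3000 nM, with a range from 1000 nM to 10000 nM.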

Compound 3, concentration for total growth inhibition: 2590 nM
Beside the measured number, compound 3's estimate is 1.2-fold (0.06 log units) above it; the measured number falls inside the stated range.
By their numbers in this assay, from the lowest: compounds 2 and 3 (each within the scatter of the next); then compound 1.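

In this assay, hydrogen in place of methyl on the oxygen on an aromatic ring, which turns methoxy into hydroxy, gives a 1.3-fold higher number from compound 2 to compound 3 (0.11 log units; within the scatter), so this read-out does not separate the two forms of the group when the rest of the structure is held constant. Compound 3 also supplies a single-place comparison with compound 1: trifluoromethyl in place of hydrogen on an aromatic carbon, with the 4-chloro-3-hydroxyphenyl group unchanged, gives a 4.9-fold lower number from compound 1 to compound 3 (0.69 log units; beyond the scatter), and of the two steps now readable, only this one lies beyond the scatter. Nothing shown here offers an explanation for either step.

As far as these compounds go, what remains open is whether the oxygen tolerates anything larger or different, such as an ethoxy group, or whether an amine or a carboxylic acid in place of the hydroxy would read the same way. From the compounds shown here alone, it is also open whether the trifluoromethyl step holds with methoxy in place of hydroxy, and whether a chlorine or a nitrile could stand in place of that trifluoromethyl.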